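Benzothiazole-amide series: cyclopropylcarbonyl for cyclopropyl step

The source may report more compounds than this note shows. Statements on the series, on what has been measured and on what is new or still open speak of the compounds shown alone.

Measured compounds:
- compound 1 `COc1c(NS(=O)(=O)c2ccc(F)cc2)cc(-c2ccc3nc(NC(C)=O)sc3c2)cc1C(N)=O` — in a functional assay on A549 cells (Homo sapiens) for antiproliferative activity, read by MTT assay, with a stated time of 72 h (on this read-out lower numbers stand for stronger inhibition and higher numbers for weaker inhibition), compound 1 gives 1700 nM
- compound 2 `NC(=O)c1cc(NS(=O)(=O)c2ccc(F)cc2)cc(-c2ccc3nc(NC(=O)C4CC4)sc3c2)c1` — in this assay compound 2 gives "not determined" (no result reported)
- compound 3 `COc1c(NS(=O)(=O)c2ccc(F)cc2)cc(-c2ccc3nc(NC4CC4)sc3c2)cc1C(N)=O` — in this assay compound 3 gives "not determined" (no result reported)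

Within the data shown here, compound 3 therefore stands without a number in this assay; compound 2 likewise has none, so compound 1 supplies the only number in the set. Compound 4 `COc1c(NS(=O)(=O)c2ccc(F)cc2)cc(-c2ccc3nc(NC(=O)C4CC4)sc3c2)cc1C(N)=O` is not yet measured. The change from compound 3 to compound 4 is cyclopropylcarbonyl in place of cyclopropyl on a nitrogen on an aromatic ring. Among the measured compounds shown here, no step between two measured compounds is available to size this change, and compound 3 itself gives no anchor. Compound 1 is the nearest measured neighbour of compound 4 and is taken as the reference. For the measured compounds named here, with no measured step to lean on, the expected difference for compound 4 in this assay is taken as none beyond the scatter, with wide uncertainty. Compound 4 is expected to give 1500 nM in this assay, within 400 nM to 6000 nM.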

Compound 4, half-maximal inhibitory concentration: 6340 nM
For compound 4 the middle estimate is 4.2-fold (0.63 log units) below the measured one, and the stated range ends below it.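

On the carbonyl carbon of the amide, the group is shown to matter for the first time: in this assay, cyclopropyl in place of methyl gives a 3.7-fold higher number from compound 1 to compound 4 (0.57 log units; beyond the scatter). The step from cyclopropyl to cyclopropylcarbonyl on the nitrogen cannot be read, as compound 3 has no single number. Nothing available explains the change in compound 4.

Open, going by these compounds, is whether an ethyl group or a longer chain on this carbonyl carbon would follow the same direction. Also open, on these data alone, is how a free amine at this nitrogen would compare.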